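Notes on a four-compound cytotoxicity series

The source may hold more compounds than are shown below. What is called first, only, known or untested is meant among the compounds shown, and "the series" means these compounds.

Measured compounds:
compound 1 `C=C1C[C@]23C[C@@]1(O)CC[C@@H]2c1cccc(C)c1[C@@H]3Cn1cc(-c2ccc(OC)cc2)nn1`: > 20000 nM
compound 2 `COc1ccc(-c2cn(C[C@H]3c4c(ccc(OS(=O)(=O)c5ccc(C)cc5)c4C)[C@@H]4CC[C@@]5(C)C[C@]43CC5=O)nn2)cc1`: > 20000 nM
compound 3 `C=C1C[C@]23C[C@@]1(O)CC[C@@H]2c1cccc(C)c1[C@@H]3Cn1cc(-c2ccc(Br)cc2)nn1`: > 20000 nM

In a functional assay on SW480 cells (Homo sapiens) for cytotoxicity, read by MTT assay, with a stated time of 4 days (on this read-out higher numbers stand for weaker inhibition and lower numbers for stronger inhibition), compound 1 gives > 20000 nM, which is a limit of the assay and not a number. Compound 3 likewise gives > 20000 nM in this assay, again a limit. Compound 2 gives > 20000 nM in this assay, also a limit.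

Compound 3 differs from compound 1 by bromo in place of methoxy on an aromatic carbon. The step that the two limits leave unreadable from compound 1 to compound 3 cannot be read, since both ends are limits; all that can be said rests on (the limit of > 20000 nM in this assay, at which 3 of the 3 values shown sit). How the core of compound 2 differs from the core of compound 1 is not broken down here.

The unmeasured compound 4 `Cc1ccc(S(=O)(=O)Oc2ccc3c(c2C)[C@H](Cn2cc(-c4ccc(Br)cc4)nn2)[C@@]24CC(=O)[C@@](C)(CC[C@@H]32)C4)cc1` differs from compound 2 by bromo in place of methoxy on an aromatic carbon. Going by the values given here, this is the same change as that from compound 1 to compound 3, at the same place, so the pair of compound 1 and compound 3 is the only guide to it. That pair shows no readable step, and every measured value sits at the limit, so no size can be assigned to the change; the expectation is that compound 4 also falls at or beyond the limit.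

Compound 4 is therefore expected to give 30000 nM in this assay. The step that the limit leaves unreadable from compound 2 to compound 4 is the estimated outcome, with a limit the most likely report.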

Compound 4, half-maximal inhibitory concentration: > 20000 nM
Compound 4 gave a limit, no number; the forecaster's own chance of this, stated with the estimate: 85%; the middle value does not contradict the limit.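

In this assay compound 4 gives > 20000 nM, a limit of the assay and not a number. The step between compound 2 and compound 4 cannot be read, since both ends are limits: the limit of > 20000 nM in this assay, at which 4 of the 4 values shown sit.

The compounds shown leave open whether bromo in place of methoxy alters the read-out at all on either core, and how large any such change would be.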